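Hydroxyphenyl Position Shift and Topoisomerase 1 Inhibition

The source may hold more compounds than are shown below. What is called first, only, known or untested is meant among the compounds shown, and "the series" means these compounds.

Compound 1 `Oc1cccc(-c2cc(-c3ccco3)cc(-c3ccccc3O)n2)c1` and compound 2 `Oc1ccc(-c2cc(-c3ccco3)cc(-c3ccccc3O)n2)cc1` share one core. In an assay on isolated protein for inhibition of DNA topoisomerase 1 (Homo sapiens), with a stated time of 30 min, tested at 20 uM (a higher number here means a stronger effect of the compound at the concentration tested, a lower number a weaker effect), compound 1 gives 0% and compound 2 gives 0%. The change 4-hydroxyphenyl in place of 3-hydroxyphenyl on an aromatic carbon yields the step of no change at the digits printed from compound 1 to compound 2 (within the scatter). Compound 3 `Oc1cccc(-c2cc(-c3ccoc3)cc(-c3cccc(O)c3)n2)c1` has a different core; the difference between the two cores is not broken down here. In this assay compound 3 gives 2%. Compound 4 `Oc1ccc(-c2cc(-c3ccoc3)cc(-c3cccc(O)c3)n2)cc1` differs from compound 3 by 4-hydroxyphenyl in place of 3-hydroxyphenyl on an aromatic carbon, the same kind of change as from compound 1 to compound 2, though here the place is meta to a 3-hydroxyphenyl group and meta to a furan-3-yl group, whereas in compound 1 it is meta to a 2-hydroxyphenyl group and meta to a furan-2-yl group. Because compound 3 gives 2% and the earlier step was no change at the digits printed from compound 1 to compound 2 (within the scatter), the step from compound 3 to compound 4 is expected to be no change at the digits printed from compound 3 to compound 4 (within the scatter). Compound 4 is therefore estimated at 2%, between -5% and 10%.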

Compound 4, a percentage reported as inhibition, at one concentration (the size of the read-out at that concentration, not a potency): 1.3%
Compound 4: middle estimate off by 0.7 percentage points, on the high side; the measured number falls inside the stated range.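

In this assay, putting 4-hydroxyphenyl in place of 3-hydroxyphenyl on the core of compound 3 gives a number 0.7 percentage points lower from compound 3 to compound 4 (within the scatter). The change reads the same on both cores: the same change on two cores in this assay, no change at the digits printed (within the scatter) from compound 1 to compound 2 and a number 0.7 percentage points lower (within the scatter) from compound 3 to compound 4, 0.7 percentage points apart, within the scatter of two such steps. Going by these compounds alone, this shows only that the change leaves the read-out unmoved on these two cores at the single concentration tested, and since all four compounds sit at the floor of the read-out, it does not show whether the change would carry over on a core with a clear effect.

On these data alone, it remains open whether any other group on these phenyl rings, such as an amine or a carboxylic acid in place of the hydroxyl, would give a larger read-out in this assay. As far as these compounds go, the effect of a longer chain at that place is equally open.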